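A few compounds are considered here, and "the series" means these few. Any claim that something is new, unique, unknown or untested is made for them only; others in the source may bear on it.

Among the compounds with values here, in an in vitro functional assay on cells for agonist activity at Bombesin receptor subtype-3 (Mus musculus), read by luminescence and calcium flux (a lower number here means that less compound is needed, a higher number that more compound is needed for the effect), compound 2 `O=C(O)c1ccccc1-c1ccc(CCc2ncc(Cc3ccccc3Cl)[nH]2)cc1` gives 22 nM, the lowest of the three numbers measured so far: compound 1 `CCCCc1cnc(C(C)Cc2ccc(-c3ccccc3C(=O)O)cc2)[nH]1` gives 184 nM and compound 3 `N#Cc1ccccc1Cc1cnc(CCc2ccc(-c3ccccc3C(=O)O)cc2)[nH]1` gives 642 nM. Compound 4 `COc1ccccc1Cc1cnc(CCc2ccc(-c3ccccc3C(=O)O)cc2)[nH]1` differs from compound 2 in a single place: methoxy in place of chloro on an aromatic carbon. Within the data shown here, the only measured step that bears on this change is a 29-fold higher number from compound 2 to compound 3 (1.47 log units; beyond the scatter), where replacing the same chloro brought a large loss. Methoxy is a different entering group from cyano, so the loss expected for compound 4 is taken to be smaller, though still a step in this assay toward a higher number, estimated as a 3.2-fold higher number from compound 2 to compound 4 (0.50 log units; beyond the scatter). Compound 4 is therefore expected to give about 70 nM, within a range from 20 nM to 300 nM.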

Compound 4, half-maximal effective concentration: 163 nM
The estimate for compound 4 lay 2.3-fold (0.37 log units) below the measured number, and the stated range covers the measured number.
By their numbers in this assay, from the lowest: compound 2; then compounds 4 and 1 (each within the scatter of the next); then compound 3.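

In this assay, a second group in place of chloro on this aromatic carbon also raises the number, with a 7.4-fold higher number from compound 2 to compound 4 (0.87 log units; beyond the scatter), so neither entering group shown matches chloro here. The size of the loss depends on the entering group, with methoxy in place of cyano giving a 3.9-fold lower number from compound 3 to compound 4 (0.60 log units; beyond the scatter). Nothing available explains this difference between the groups. On these data alone, what a fluoro, a methyl or an amine would give at this place stays open, as does whether any group here would give a lower number than chloro.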